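The source may report more compounds than this note shows. Statements on the series, on what has been measured and on what is new or still open speak of the compounds shown alone.

Measured compounds:
- compound 1, `CCN1CCN(c2cc(C)c3cc(NC(=O)c4cc(Cl)cc(Cl)c4)ccc3n2)CC1`: 2660 nM
- compound 2, `Cc1cc(N2CCN(C)CC2)nc2ccc(NC(=O)c3ccc(Cl)c(Cl)c3)cc12`: 6320 nM
- compound 3, `CCN1CCN(c2cc(C)c3cc(NC(=O)c4ccco4)ccc3n2)CC1`: 37500 nM

In a functional assay on SK-BR-3 cells (Homo sapiens) for antiproliferative activity, read by MTT assay, with a stated time of 72 h (a higher number here means a weaker inhibitor, a lower number a stronger inhibitor), compound 1 has the lowest number of the three. The step to compound 3 is large, a 14-fold higher number from compound 1 to compound 3 (1.15 log units; beyond the scatter), and shows that the group on the carbonyl carbon matters. Compound 4, `CCN1CCN(c2cc(C)c3cc(NC(=O)c4ccc(Cl)c(Cl)c4)ccc3n2)CC1`, differs from compound 1 by 3,4-dichlorophenyl in place of 3,5-dichlorophenyl on a carbonyl carbon. Among the measured compounds shown here, no measured step changes only this, but compound 2, which carries the same 3,4-dichlorophenyl on a slightly different core, gives 6320 nM in this assay, a somewhat higher number than compound 1. Compound 4 is therefore expected to show a modest rise, a 1.7-fold higher number from compound 1 to compound 4 (0.23 log units; within the scatter), with the estimate for compound 4 at 4500 nM, between 1500 nM and 13000 nM.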

Compound 4, half-maximal inhibitory concentration: 2160 nM
The estimate for compound 4 lay 2.1-fold (0.32 log units) above the measured number; measured number inside the range.
By their numbers in this assay, from the lowest: compounds 4 and 1 (each within the scatter of the next); then compound 2; then compound 3.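

Exchanging 3,5-dichlorophenyl for 3,4-dichlorophenyl on the carbonyl carbon makes no real difference in this assay (a 1.2-fold lower number from compound 1 to compound 4 (0.09 log units; within the scatter)), so both dichlorophenyl patterns are tolerated here. The large gap from furan-2-yl also holds for this second dichlorophenyl group (a 17-fold lower number from compound 3 to compound 4 (1.24 log units; beyond the scatter)). A second place matters too: methyl in place of hydrogen on a saturated chain carbon bound to an amine nitrogen in a ring gives a modest change (a 2.9-fold lower number from compound 2 to compound 4 (0.47 log units; beyond the scatter)). Going by these compounds, whether an amine on the phenyl ring or a longer chain on that ring nitrogen would lower the number remains open. Nothing available explains these steps.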